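Notes on amide toxicity in the shared-core series

The source may hold more compounds than are shown below. What is called first, only, known or untested is meant among the compounds shown, and "the series" means these compounds.

Compound 2 `COc1ccc(-c2cnc(NC(=O)c3cccc(OC)c3)n2C)cc1` is the reference point. In a toxicity assay on THP-1 cells (Homo sapiens) for inhibition (on this read-out lower numbers stand for higher toxicity in this test and higher numbers for lower toxicity in this test), compound 2 reaches only a limit of the assay, > 100000 nM. Compound 1 `COc1ccccc1-c1cnc(NC(=O)c2ccc(F)cc2)n1C` likewise gives a limit in this assay, > 100000 nM. Compound 3 `Cc1cccc(-c2cnc(NC(=O)c3ccc(F)cc3)n2C)c1` also gives a limit in this assay, > 100000 nM. Among the measured compounds shown here, the single measured step with one change is a step that the two limits leave unreadable from compound 1 to compound 3, which cannot be read because of the limit of > 100000 nM in this assay, at which 3 of the 3 values shown sit. Compound 4 `CCC(=O)Nc1ncc(-c2ccc(OC)cc2)n1C` differs from compound 2 by ethyl in place of 3-methoxyphenyl on a carbonyl carbon. For the measured compounds named here, no measured step bears on this change, and every value in this assay so far rests at the same limit. The expected step is a number no higher from compound 2 to compound 4 (the limit leaves the size open), nothing beyond the scatter. Compound 4 is therefore expected near the limit in this assay, estimated at 100000 nM with a range from 40000 nM to 300000 nM.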

Compound 4, half-maximal cytotoxic concentration: > 100000 nM
Compound 4: only a limit was reported; the forecaster's own chance of this, stated with the estimate: 85%; the middle value sits exactly at the limit.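

No step can be read from compound 2 to compound 4 in this assay, because both results are limits: the limit of > 100000 nM in this assay, at which 4 of the 4 values shown sit.

The compounds shown leave open whether ethyl in place of 3-methoxyphenyl on a carbonyl carbon changes toxicity at all.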